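Methyl on the Chain of Compound 3

A few compounds are considered here, and "the series" means these few. Any claim that something is new, unique, unknown or untested is made for them only; others in the source may bear on it.

Values in a functional assay on the whole organism for inhibition, with Rattus norvegicus as the target (a lower number here means that less compound is needed, a higher number that more compound is needed for the effect), are these:
Compound 1 (`CC(C)c1ccc(OC(C)(Cc2ccc(Cl)cc2)C(=O)NS(C)(=O)=O)cc1`) gives 5 mg/kg
Compound 2 (`Cc1ccccc1S(=O)(=O)NC(=O)C(C)(Cc1ccc(Cl)cc1)Oc1ccc(C(C)C)cc1`) gives > 10 mg/kg as a limit
Compound 3 (`COc1ccc(S(=O)(=O)NC(=O)C(C)(Cc2ccc(Cl)cc2)Oc2ccc(C(C)C)cc2)cc1`) gives > 10 mg/kg as a limit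

Compound 3 stands at a limit and not at a number. This is the limit of > 10 mg/kg in this assay, at which 2 of the 3 values shown sit, and it does not rank compound 3 any further. Compound 4 (`COc1ccc(S(=O)(=O)NC(=O)C(C)(Oc2ccc(C(C)C)cc2)C(C)c2ccc(Cl)cc2)cc1`) differs from compound 3 by one change (methyl in place of hydrogen on a saturated chain carbon bound to an aromatic carbon and a saturated chain carbon) with methyl in place of hydrogen on a saturated chain carbon bound to an aromatic carbon and a saturated chain carbon. For the measured compounds named here, no measured step makes this change. The steps of an at least 2.0-fold higher number from compound 1 to compound 2 (0.30 log units; that floor lies within the scatter) and an at least 2.0-fold higher number from compound 1 to compound 3 (0.30 log units; that floor lies within the scatter) concern only the group on the sulfonyl sulfur and give no size for it. In this assay the expectation is therefore no step beyond the scatter, an expected step that the limit leaves unreadable from compound 3 to compound 4 from a start that is only a limit. Compound 4 is estimated at 12 mg/kg within an expected range of 5 mg/kg to 30 mg/kg for the coming measurement.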

Compound 4, dose for half-maximal effect: > 10 mg/kg
Compound 4 gave a limit, no number; the forecaster's own chance of this, stated with the estimate: 70%; the middle value does not contradict the limit.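

Compound 4 gives > 10 mg/kg, a limit and not a number; compound 3 also stands at a limit, so no step from compound 3 to compound 4 can be read: the limit of > 10 mg/kg in this assay, at which 3 of the 4 values shown sit.

The compounds shown leave open what size of effect, if any, the change from 4-chlorobenzyl to 1-(4-chlorophenyl)ethyl has.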